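The compounds below may be only part of what the source reports. "The series", "measured", "known", "first", "only" and "open" are said of these compounds alone.

Compound 1 `COc1ccc(-c2csc(N)c2C(=O)OCc2ccccc2)cc1OC` and compound 2 `CCOC(=O)c1c(-c2ccc(C)cc2)csc1N` share a core that carries an amino group and an ester, and each was tested in an assay on isolated protein for inhibition of protein kinase C zeta type (Homo sapiens), with stated times of 1 h and 2.5 min, tested at 30 uM; on this read-out lower numbers stand for less inhibition and higher numbers for more inhibition at the one concentration tested (going by the name of the read-out). In this assay compound 1 gives 100%, while compound 2 gives 80%. Compound 2 thus stands lowest of the two numbers, with compound 1 sitting a distance above it that lies beyond the usual scatter of repeated measurements. Since the two compounds differ in more than one place, the gap between them cannot be tied to any single change.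

Compound 3 `CCOC(=O)c1c(-c2ccc(N)cc2)csc1N` has not yet been measured in this assay. It differs from compound 2 in one place: amino in place of methyl on an aromatic carbon. Nothing measured here shows how such a change acts on this core, so the step can only be guessed. A small step is expected from compound 2 to compound 3, a number 5 percentage points lower from compound 2 to compound 3 (within the scatter), which may well stay within the scatter, with no clear direction to be read from the data. Compound 3 is therefore estimated at 75%, in a range from 50% to 95%.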

Compound 3, a percentage reported as inhibition, at one concentration (the size of the read-out at that concentration, not a potency): 100%
Beside the measured number, compound 3's estimate is 25 percentage points below it; the measured number lies above the stated range.
By their numbers in this assay, from the lowest: compound 2; then compounds 1 and 3 (each within the scatter of the next).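

In this assay, the place on the six-membered aromatic ring para to a large group turns out to respond to a single change: with amino in place of methyl there is a number 20 percentage points higher from compound 2 to compound 3 (beyond the scatter). Among the compounds shown here, this is the first change at one place on the shared core that can be read, and it shows that the methyl is not required at this position for inhibition at the one concentration tested, as compound 3, which carries amino instead, gives 100%. The data offer no measurement that explains why this exchange acts as it does.

The compounds shown leave open whether the rise belongs to amino specifically or would also appear with other groups at this place, such as a hydroxyl, an acetamide or a carboxylic acid, or with a bare hydrogen. They also leave open how far compound 2 and compound 3 differ in potency, since a percentage at a single concentration is not a potency, and whether the same exchange would act alike with the benzyl ester and dimethoxy pattern of compound 1.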